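The compounds below may be only part of what the source reports. "The series", "measured", "known", "first", "only" and "open" are said of these compounds alone.

Compound 3 `CC(c1ccc(-c2ccccc2)c(F)c1)c1nnc2n1N=C(c1ccc([N+](=O)[O-])cc1)CS2` and compound 1 `CC(c1ccc(-c2ccccc2)c(F)c1)c1nnc2n1N=C(c1ccc(C(F)(F)F)cc1)CS2` share one core and differ in a single group. In a functional assay on Huh-7 cells (Homo sapiens) for inhibition, read by sulforhodamine B assay, with a stated time of 72 h (a lower number here means a stronger inhibitor, a higher number a weaker inhibitor), compound 3 gives 4300 nM, while compound 1 gives 9400 nM; the change trifluoromethyl in place of nitro on an aromatic carbon therefore brings a 2.2-fold higher number from compound 3 to compound 1 (0.34 log units; beyond the scatter), a modest loss. Compound 2 `CC(C)Cc1ccc(C(C)c2nnc3n2N=C(c2ccc([N+](=O)[O-])cc2)CS3)cc1` rests on a different core, and how that core differs from the core of compound 3 is not broken down here. In this assay compound 2 is reported as "not active" (no number reported), with no number attached. Compound 4 `CC(C)Cc1ccc(C(C)c2nnc3n2N=C(c2ccc(C(F)(F)F)cc2)CS3)cc1` arises from compound 2 by the same change, (trifluoromethyl in place of nitro on an aromatic carbon), at the same place. Because compound 2 shows "not active" (no number reported) and the same change elsewhere gave a 2.2-fold higher number from compound 3 to compound 1 (0.34 log units; beyond the scatter), only a weak result is expected for compound 4, quite possibly again without a number. The estimate for compound 4 in this assay is 25000 nM, expected to lie between 8000 nM and 100000 nM.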

Compound 4, half-maximal inhibitory concentration: 8400 nM
Compound 4: the middle estimate sits 3.0-fold (0.47 log units) above what was measured; the range from low to high includes it.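

Compound 2 carries no number, and the step from it to compound 4 cannot be read. The compounds shown leave open how far trifluoromethyl in place of nitro shifts the number on the core of compound 2. No measurement at hand accounts for the result.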